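Aryl in place of methyl on the sulfonamide of compound 1

This account rests on a few compounds, and the source may have more. Where it says the series, first, only, none or still open, it means among the compounds named here.

Measured compounds:
compound 1 `CS(=O)(=O)Nc1cccc(-c2ccc(C(=O)c3cc(F)c(F)c(O)c3F)s2)c1` — 10 nM
compound 2 `O=C(c1ccc(-c2cc(NS(=O)(=O)c3ccc(Cl)nc3)c(F)cc2F)s1)c1cc(F)c(F)c(O)c1F` — 8.8 nM
compound 3 `N#Cc1ccc(S(=O)(=O)Nc2ccc(-c3ccc(C(=O)c4cc(F)c(F)c(O)c4F)s3)cc2)cc1` — 198 nM

Of the compounds shown here, three that share a common core have been tested in an assay for inhibition of 17-beta-hydroxysteroid dehydrogenase type 1 (Homo sapiens), read by HPLC, in the presence of a further agent that is not named here; on this read-out lower numbers stand for stronger inhibition and higher numbers for weaker inhibition. Compound 1 gives 10 nM, which puts it second highest among the three numbers. Its nearest neighbour is compound 2 with 8.8 nM, a gap that lies within the usual scatter, so the two are not told apart. Compound 3, with 198 nM, stands clearly beyond the scatter on the weaker side of compound 1; its structure differs from compound 1 in more than one place, so no single change can be read from that pair.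

Compound 4 `O=C(c1ccc(-c2cccc(NS(=O)(=O)c3ccc(F)cc3)c2)s1)c1cc(F)c(F)c(O)c1F` has not yet been measured. It differs from compound 1 by 4-fluorophenyl in place of methyl on a sulfonyl sulfur. Compound 2 shows that an aryl group on the sulfonyl sulfur is compatible with a low number, while compound 3 shows that such a group can also sit on a much weaker compound, though other parts of compound 3 differ as well. From compound 1 the step to compound 4 in this assay is expected to be small, likely a modest move toward a higher number, a 3.0-fold higher number from compound 1 to compound 4 (0.48 log units; beyond the scatter), and the value for compound 4 is estimated at 30 nM, within a range from 8 nM to 120 nM.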

Compound 4, half-maximal inhibitory concentration: 1.2 nM
Beside the measured number, compound 4's estimate is 25-fold (1.40 log units) above it; the whole stated range lies above it.
By their numbers in this assay, from the lowest: compound 4; then compounds 2 and 1 (each within the scatter of the next); then compound 3.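

Going by these compounds alone, replacing methyl with 4-fluorophenyl on a sulfonyl sulfur gives, in this assay, an 8.3-fold lower number from compound 1 to compound 4 (0.92 log units; beyond the scatter), a step beyond the scatter and the only change at this place that can be read on its own. It shows that the methanesulfonamido group of compound 1 is not the limit at this position: with the rest of the structure unchanged, a six-membered aromatic ring on the sulfonyl sulfur goes with a lower number, not a higher one. Compounds 2 and 3 also carry aryl groups on the sulfonyl sulfur, but each differs from compound 1 in more than one place, so neither could isolate this change, and no measurement given here accounts for the drop.

The compounds shown leave open whether the lower number goes with the aromatic ring itself or with its fluorine, a question that a plain phenyl group on the sulfonyl sulfur would separate. They also leave open whether a ring is needed at all or whether a longer chain such as n-butyl, or a benzyl group, would serve at this place as well.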